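The source may report more compounds than this note shows. Statements on the series, on what has been measured and on what is new or still open speak of the compounds shown alone.

The series gathers three stereochemical variants of one scaffold and asks how much they harm mouse fibroblasts. Compound 3, `O=[N+]([O-])c1cn2c(n1)[S+]([O-])CC(OCc1ccc(OC(F)(F)F)cc1)C2`, is drawn without a configuration at either stereocentre. In an ADME assay on L929 cells (Mus musculus) for cytotoxicity (on this read-out higher numbers stand for weaker inhibition and lower numbers for stronger inhibition), compound 3 gives > 10 ug/mL, a limit of the assay rather than a number. Compound 1, `O=[N+]([O-])c1cn2c(n1)[S@@+]([O-])C[C@@H](OCc1ccc(OC(F)(F)F)cc1)C2`, gives in this assay the value > 10 ug/mL, again a limit. Compound 2, `O=[N+]([O-])c1cn2c(n1)[S@+]([O-])C[C@@H](OCc1ccc(OC(F)(F)F)cc1)C2`, gives in this assay the value > 10 ug/mL, also a limit. Compounds 1 and 2 share the same atoms and bonds and differ only in the configuration as drawn (the fact that compounds 1 and 2 differ only in the configuration as drawn), and the step that the two limits leave unreadable from compound 1 to compound 2 cannot be read because both sit at the limit (the limit of > 10 ug/mL in this assay, at which 3 of the 3 values shown sit). Likewise the step that the two limits leave unreadable from compound 1 to compound 3 and the step that the two limits leave unreadable from compound 2 to compound 3 stay unreadable for the same reason (the limit of > 10 ug/mL in this assay, at which 3 of the 3 values shown sit). So compound 3 stands where every compound so far stands: at the ceiling of the read-out, with no visible spread among them.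

The next compound, compound 4, `O=[N+]([O-])c1cn2c(n1)[S+]([O-])CC(OCc1ccc(OCc3ccccc3)cc1)C2`, is not yet measured. It differs from compound 3 by benzyl in place of trifluoromethyl on an oxygen on an aromatic ring. No measured step touches this part of the molecule, so nothing in the shown steps sets a size or direction for it. The account therefore expects compound 4 to remain near the limit, with a step that the limit leaves unreadable from compound 3 to compound 4 taken as no real movement. The estimate for compound 4 in this assay is 15 ug/mL, within 5 ug/mL to 50 ug/mL, pending the measurement.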

Compound 4, half-maximal inhibitory concentration: > 10 ug/mL
Compound 4 ended at the assay's limit (the forecaster's own chance of this, stated with the estimate: 65%); the middle value is on the limit's open side.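

No step can be read from compound 3 to compound 4 in this assay, since both compounds rest at the same limit of the read-out: the limit of > 10 ug/mL in this assay, at which 4 of the 4 values shown sit.

The compounds shown leave open whether benzyl in place of trifluoromethyl, or any difference in configuration, changes the cytotoxicity of the shared core at all, as none of the four gives a number rather than a limit.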